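The source may report more compounds than this note shows. Statements on the series, on what has been measured and on what is new or still open speak of the compounds shown alone.

Compound 3 `CN(C)CCCNc1nc(N/N=C/c2nccn2Cc2ccccc2)nc2ccccc12` was tested in a functional assay on NCI-H460 cells (Homo sapiens) for cytotoxicity, read by MTT assay, with a stated time of 72 h (on this read-out lower numbers stand for stronger inhibition and higher numbers for weaker inhibition), where compound 3 gives 4670 nM. Among the three compounds measured so far it stands with the second highest number: compound 2 `Cc1ccc(Cn2ccnc2/C=N/Nc2nc(NCCN(C)C)c3ccccc3n2)cc1` gives 4200 nM in this assay, a number within the scatter of that of compound 3, while compound 1 `CN(C)CCNc1nc(N/N=C/c2nccn2Cc2ccccc2)nc2ccccc12` gives 9650 nM, separated from compound 3 by a 2.1-fold lower number from compound 1 to compound 3 (0.32 log units; beyond the scatter). The step from compound 1 to compound 3 is the lengthening of the side chain on the shared core.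

Compound 4 `Cc1ccc(Cn2ccnc2/C=N/Nc2nc(NCCCN(C)C)c3ccccc3n2)cc1` differs from compound 3 by methyl in place of hydrogen on an aromatic carbon. The same change has been seen once, from compound 1 to compound 2, where it gave a 2.3-fold lower number from compound 1 to compound 2 (0.36 log units; beyond the scatter). If that modest step carries over, compound 4 is expected to show a number lower than that of compound 3 by about a 2.2-fold lower number from compound 3 to compound 4 (0.35 log units; beyond the scatter) in this assay. Compound 4 is therefore estimated at 2100 nM, with a range from 1100 nM to 4200 nM.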

Compound 4, half-maximal inhibitory concentration: 1690 nM
Compound 4: the middle estimate sits 1.2-fold (0.09 log units) above what was measured; the measured number falls inside the stated range.
By their numbers in this assay, from the lowest: compound 4; then compounds 2 and 3 (each within the scatter of the next); then compound 1.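

In this assay, among these compounds, the change from benzyl to 4-methylbenzyl, earlier seen only with the shorter side chain, now gives a 2.8-fold lower number from compound 3 to compound 4 (0.44 log units; beyond the scatter) with the longer one, so the step recurs at similar size on a second core: the same change on two cores in this assay, a 2.3-fold lower number (0.36 log units; beyond the scatter) from compound 1 to compound 2 and a 2.8-fold lower number (0.44 log units; beyond the scatter) from compound 3 to compound 4, 1.2-fold (0.08 log units) apart, within the scatter of two such steps The lengthening of the side chain, earlier seen only with the benzyl group, likewise gives a 2.5-fold lower number from compound 2 to compound 4 (0.40 log units; beyond the scatter) with the 4-methylbenzyl group in place: the same change on two cores in this assay, a 2.1-fold lower number (0.32 log units; beyond the scatter) from compound 1 to compound 3 and a 2.5-fold lower number (0.40 log units; beyond the scatter) from compound 2 to compound 4, 1.2-fold (0.08 log units) apart, within the scatter of two such steps Across these four compounds, each change therefore keeps its size whichever form the other place takes.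

The compounds shown leave open whether the step is particular to methyl or would also appear with chlorine or methoxy on the same aromatic carbon. They also leave open whether a still longer chain, or a piperidine in place of the dimethylamino end, would lower the number further.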